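The source may report more compounds than this note shows. Statements on the series, on what has been measured and on what is new or still open speak of the compounds shown alone.

Measured compounds:
Compound 1, `CCCCCCCCCCCCNc1nc2ccccc2nc1Oc1ccc(C(=O)N[C@H](C(=O)OC)[C@H](C)CC)cc1`: 43300 nM
Compound 2, `COC(=O)CNC(=O)c1ccc(Oc2nc3ccccc3nc2NC(C)(C)C)cc1`: > 50000 nM

Both compounds were tested in a functional assay on MCF7 cells (Homo sapiens) for antiproliferative activity, read by MTT assay, with a stated time of 48 h; a lower number here means a stronger inhibitor, a higher number a weaker inhibitor. Compound 1 gives 43300 nM, a weak result. For compound 2 the readout is not a number but a limit of the assay, > 50000 nM. Within the data shown here, the only evidence touching the measured values is the limit of > 50000 nM in this assay, at which 1 of the 2 values shown sits. Among the measured compounds shown here, compound 1 and compound 2 differ in several places at once, so no single step between them can be drawn; all their two values show is that neither is a strong inhibitor.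

The compound still to be measured is compound 3, `CC[C@@H](C)[C@H](NC(=O)c1ccc(Oc2nc3ccccc3nc2NC(C)(C)C)cc1)C(=O)OC`. It differs from compound 2 in one place: sec-butyl in place of hydrogen on a saturated chain carbon bound to an amide-type nitrogen and a carbonyl carbon. Compound 1 carries the same 1-(methoxycarbonyl)-2-methylbutyl group and sits just inside the measurable range, while compound 2 with the (methoxycarbonyl)methyl group does not reach it. On that basis the step of an at least 1.1-fold lower number from compound 2 to compound 3 (0.04 log units; that floor lies within the scatter) is expected to be at most a small gain, within or barely beyond the scatter. Compound 3 is therefore estimated at 45000 nM, between 15000 nM and 150000 nM, with a real chance that only a limit is reported again.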

Compound 3, half-maximal inhibitory concentration: 33400 nM
Compound 3: middle estimate off by 1.3-fold (0.13 log units), on the high side; measured number inside the range.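

Compound 2 gives only a limit of the assay in this assay, namely > 50000 nM, and so has no exact number for comparison. Sec-butyl in place of hydrogen on a saturated chain carbon bound to an amide-type nitrogen and a carbonyl carbon gives an at least 1.4-fold lower number from compound 2 to compound 3 (0.17 log units; that floor lies within the scatter), which is a floor and not a true size, so the change can only be said to bring this series to a measured number, and even that reading depends on a limit: the limit of > 50000 nM in this assay, at which 1 of the 3 values shown sits.

At the other site, tert-butyl in place of dodecyl on a nitrogen on an aromatic ring gives a 1.3-fold lower number from compound 1 to compound 3 (0.11 log units; within the scatter), so with the 1-(methoxycarbonyl)-2-methylbutyl group present, these two compounds cannot be told apart in this assay despite the different nitrogen substituents.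

On these data alone, how far the number would move with a carboxylic acid in place of the methoxycarbonyl group, or with an amine on the side chain, stays open. Also open, as far as these compounds go, is whether any change at either site could give a strong inhibitor, as all the values shown remain weak.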